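The compounds below may be only part of what the source reports. "The series", "measured", "known", "first", "only" and "open" are said of these compounds alone.

Measured so far:
Compound 1, `Cn1c(-c2cccc(F)c2)nnc1S(C)(=O)=O`: 12.1 mg/kg
Compound 2, `CSc1nnc(-c2ccccc2F)n1C`: 8.8 mg/kg
Compound 3, `Cn1c(-c2ccccc2F)nnc1S(C)(=O)=O`: 17.6 mg/kg

All three were tested in a functional assay on the whole organism for antagonist activity, with Mus musculus as the target; a higher number here means that more compound is needed for the effect, a lower number that less compound is needed. Compound 1 and compound 3 are built from the same atoms joined differently; the difference between the two cores is not broken down here, and their values lie within the scatter of each other, as do the values of compound 1 and compound 2.

Compound 2 and compound 3 differ in one place: methylsulfanyl in place of methylsulfonyl on an aromatic carbon. That exchange gave a 2.0-fold lower number from compound 3 to compound 2 (0.30 log units; within the scatter), a step that stays within the usual scatter.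

Compound 4, `CSc1nnc(-c2cccc(F)c2)n1C`, has not yet been measured in this assay. It differs from compound 1 by the same kind of change: methylsulfanyl in place of methylsulfonyl on an aromatic carbon. The description of the place is the same word for word in both pairs, so the change is the same one, made on a different core.

Among the compounds with values here, compound 4 is expected to give a step of a 1.9-fold lower number from compound 1 to compound 4 (0.27 log units; within the scatter), beside the measured one, because the only precedent, a 2.0-fold lower number from compound 3 to compound 2 (0.30 log units; within the scatter), was small and within the scatter. This rests on a single measured pair, so the expectation is loose, and the result could as well sit where compound 1 sits. The estimate for compound 4 is 6.5 mg/kg, expected to fall between 3.5 mg/kg and 13 mg/kg.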

Compound 4, dose for half-maximal effect: 13.8 mg/kg
Estimate against measurement, compound 4: 2.1-fold (0.33 log units) below; measured number outside the range, above it.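

In this assay, methylsulfanyl in place of methylsulfonyl on an aromatic carbon gave a 1.1-fold higher number from compound 1 to compound 4 (0.06 log units; within the scatter), so on this core, as on the other one, the exchange produced a step that stays within the usual scatter. Set side by side, the two steps cannot be told apart, which means that moving the change from one core to the other produced no difference that these measurements can detect: the same change on two cores in this assay, a 2.0-fold lower number (0.30 log units; within the scatter) from compound 3 to compound 2 and a 1.1-fold higher number (0.06 log units; within the scatter) from compound 1 to compound 4, 2.3-fold (0.36 log units) apart, within the scatter of two such steps. This shows that, across these two pairs, the exchange gave no readable shift in the dose needed, but it does not show that the two groups are truly equivalent, since a small real effect could be hidden in the scatter, and two pairs say nothing about how the change would behave on any further core.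

The compounds shown carry only methylsulfonyl or methylsulfanyl on this aromatic carbon, so it remains open whether an amine, a methoxy group or a longer chain such as ethylsulfanyl in that place would give a step beyond the scatter. Also open, on these data alone, is what would happen if the methyl group on the neighbouring ring atom were exchanged for another group.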